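Swapping a Pyrimidine for Cyclohexyl on the Amide Carbonyl

A few compounds are considered here, and "the series" means these few. Any claim that something is new, unique, unknown or untested is made for them only; others in the source may bear on it.

Three compounds share one core and differ only in the group attached to the amide carbonyl carbon. Compound 1 `O=C(Nc1ccc(Cl)cc1CN1C(=O)c2ccccc2C1=O)c1ccco1` gives 2300 nM in an assay on CHO cells for positive allosteric modulation of metabotropic glutamate receptor 5 (Homo sapiens), read by FLIPR; a lower number here means that less compound is needed, a higher number that more compound is needed for the effect. Compound 2 `O=C(Nc1ccc(Cl)cc1CN1C(=O)c2ccccc2C1=O)c1ccccc1C(F)(F)F` gives 5700 nM in this assay, and compound 3 `O=C(Nc1ccc(Cl)cc1CN1C(=O)c2ccccc2C1=O)c1ncccn1` gives 2100 nM in this assay. Compound 3 has the lowest number of the three, though its gap to compound 1 is within the scatter: a 1.1-fold lower number from compound 1 to compound 3 (0.04 log units; within the scatter). Against compound 2 the gap is wider: a 2.7-fold lower number from compound 2 to compound 3 (0.43 log units; beyond the scatter), and likewise a 2.5-fold higher number from compound 1 to compound 2 (0.39 log units; beyond the scatter). Compound 4 `O=C(Nc1ccc(Cl)cc1CN1C(=O)c2ccccc2C1=O)C1CCCCC1` is the next step, with cyclohexyl in place of pyrimidin-2-yl on a carbonyl carbon. Within the data shown here, no measured step exchanges an aromatic ring for a non-aromatic ring here, so the direction of the change is open. The three measured steps show that a swap on this carbonyl carbon shifts the number by a modest amount at most. A modest change is therefore expected, a 1.7-fold higher number from compound 3 to compound 4 (0.22 log units; within the scatter), with the direction uncertain. Compound 4 is estimated at 3500 nM, expected to fall between 1200 nM and 10000 nM.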

Compound 4, half-maximal effective concentration: 1500 nM
For compound 4 the middle estimate is 2.3-fold (0.37 log units) above the measured one; the measured number falls inside the stated range.
By their numbers in this assay, from the lowest: compounds 4, 3 and 1 (each within the scatter of the next); then compound 2.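

Cyclohexyl is the first ring on this carbonyl carbon that is non-aromatic and made of carbon only, with no hydrogen-bond acceptors, yet in this assay the exchange for pyrimidin-2-yl stays within the scatter (a 1.4-fold lower number from compound 3 to compound 4 (0.15 log units; within the scatter)), as does the exchange for furan-2-yl (a 1.5-fold lower number from compound 1 to compound 4 (0.19 log units; within the scatter)). Among these four compounds, then, neither an aromatic ring nor a ring with hetero atoms is required at this position, and only 2-(trifluoromethyl)phenyl stands apart (a 3.8-fold lower number from compound 2 to compound 4 (0.58 log units; beyond the scatter)). Nothing available explains why these different rings give such similar numbers.

Going by these compounds, it remains open whether cyclopropyl, a longer chain such as n-butyl, or a ring carrying an amine such as piperidin-4-yl would keep the number in this range. Also open, on these data alone, is whether unsubstituted phenyl would read like 2-(trifluoromethyl)phenyl or like the other three groups.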